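Compound 1 and its ethyl ester, compound 4

The source may hold more compounds than are shown below. What is called first, only, known or untested is meant among the compounds shown, and "the series" means these compounds.

Measured so far:
compound 1 `O=C(O)c1cnc(-c2ccccc2O)[nH]c1=O`: > 5 mg/kg (a limit)
compound 2 `CC(C)COc1ccccc1-c1ncc(C(=O)O)c(=O)[nH]1`: 0.5 mg/kg
compound 3 `C[S+]([O-])c1ccccc1-c1ncc(C(=O)O)c(=O)[nH]1`: > 5 mg/kg (a limit)

The read-out throughout is a functional assay on the whole organism (strain Sprague-Dawley) for inhibition, with Rattus norvegicus as the target, with a stated time of 10 min; on this read-out higher numbers stand for an effect only at larger amounts of compound and lower numbers for an effect already at smaller amounts. In this assay compound 1 gives > 5 mg/kg, which is a limit and not a number. It therefore marks no exact place on the scale, and the set as a whole shows (the limit of > 5 mg/kg in this assay, at which 2 of the 3 values shown sit).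

Compound 4 `CCOC(=O)c1cnc(-c2ccccc2O)[nH]c1=O` differs from compound 1 by one change: ethyl in place of hydrogen on an oxygen next to a carbonyl group. In other words, carboxy becomes ethoxycarbonyl.

Going by the values given here, no measured step touches this carboxy group, so nothing here tests the change directly. The nearest step in kind is an at least 10-fold lower number from compound 1 to compound 2 (1.00 log units; beyond the scatter). It also puts a carbon chain on an oxygen, but there the isobutyl sits on an oxygen on an aromatic ring, not on an oxygen next to a carbonyl group. That makes it only a loose guide. The step that the two limits leave unreadable from compound 1 to compound 3 adds nothing readable.

A large drop in the number is therefore not expected, and compound 4 is expected to stay near the limit reached by compound 1. The expected step is a step that the limit leaves unreadable from compound 1 to compound 4, with no clear change beyond the scatter anticipated. For compound 4 the estimate is 8 mg/kg, with an expected range from 2.5 mg/kg to 25 mg/kg.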

Compound 4, dose for 50% inhibition: 5 mg/kg
Beside the measured number, compound 4's estimate is 1.6-fold (0.20 log units) above it, and the stated range covers the measured number.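

In this assay compound 4 gives 5 mg/kg, the only exact number among the compounds shown that keep the hydroxy group on the aromatic ring, and the only result for any change at the carboxy group. Compound 1 gives > 5 mg/kg, which is a limit. The data print a number no higher from compound 1 to compound 4 (the limit leaves the size open), so the result shows that an exact dose can be obtained with ethoxycarbonyl in place of carboxy, but not how much the ethyl contributes, and the set still holds values at one limit: the limit of > 5 mg/kg in this assay, at which 2 of the 4 values shown sit.

Going by these compounds alone, still open is what ethoxycarbonyl does when the hydrogen on the oxygen on the aromatic ring is also replaced by isobutyl, the change that gave the one clear step so far. Also open, going by these compounds, is whether a longer chain than ethyl on this oxygen, or an amide in place of the carboxy group, would move the number in either direction, and a compound with an exact value at both ends of such a change would be needed to size that step.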